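The source may report more compounds than this note shows. Statements on the series, on what has been measured and on what is new or still open speak of the compounds shown alone.

Working notes on the series, read in a functional assay on SGC-7901 cells (Homo sapiens) for inhibition, read by MTT assay, with a stated time of 72 h; on this read-out lower numbers stand for stronger inhibition of growth and higher numbers for weaker inhibition of growth. Compound 1 (`O[C@H](COCCOC[C@@H](O)Cc1cn(Cc2ccc3ccccc3c2)nn1)Cc1ccc(-c2ccccc2)cc1`) gives 12100 nM, compound 2 (`COC1=C(OC)C(=O)C(CCCCCCCCCCn2cc(C[C@H](O)COCCOC[C@@H](O)Cc3ccc(-c4ccccc4)cc3)nn2)=C(C)C1=O`) gives 3800 nM and compound 3 (`O=C1COc2ccc(-n3cc(C[C@H](O)COCCOC[C@@H](O)Cc4ccc(-c5ccccc5)cc4)nn3)cc2N1`) gives 15200 nM. Compound 3 sits at the upper end of these numbers together with compound 1, and the two are not separated. Compound 2 has the lower number, and its gap to compound 3 lies beyond the scatter.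

Compound 4 (`O[C@H](COCCOC[C@@H](O)Cc1cn(-c2cccnc2)nn1)Cc1ccc(-c2ccccc2)cc1`) changes the group on an aromatic nitrogen: a group of 6 heavy atoms (5 carbon, 1 nitrogen; one six-membered aromatic ring with 1 hetero atom) in place of a group of 11 heavy atoms (8 carbon, 1 nitrogen, 2 oxygen; one six-membered non-aromatic ring with 2 hetero atoms, one six-membered aromatic ring of carbon only), on an aromatic nitrogen. Within the data shown here, the only measured step at this place is a 1.3-fold higher number from compound 1 to compound 3 (0.10 log units; within the scatter). Among the measured compounds shown here, that step exchanges one group for another of equal heavy-atom count, so no measured step covers a smaller group here. For the measured compounds named here, compound 2 shows that the group on this nitrogen can go with a different number, but no measured step links it directly to compound 3. On the evidence of compound 3 and compound 1, no step beyond the scatter is expected in this assay, though the uncertainty is wide. The estimate means a 1.0-fold lower number from compound 3 to compound 4 (0.01 log units; within the scatter), an expected step within the scatter. For compound 4 the estimated value is 15000 nM, with an expected range from 7000 nM to 35000 nM.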

Compound 4, concentration for 50% growth inhibition: 29800 nM
Beside the measured number, compound 4's estimate is 2.0-fold (0.30 log units) below it; measured number inside the range.
By their numbers in this assay, from the lowest: compound 2; then compounds 1, 3 and 4 (each within the scatter of the next, the first and the last beyond it).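

In this assay, the change to the smaller pyridin-3-yl group on the aromatic nitrogen gives two different readings. Against the group of compound 3, a 2.0-fold higher number from compound 3 to compound 4 (0.29 log units; within the scatter) does not separate the two compounds, whereas against (naphthalen-2-yl)methyl, a 2.5-fold higher number from compound 1 to compound 4 (0.39 log units; beyond the scatter) is a modest step that clears the scatter, the first separated step measured among these groups without the long chain of compound 2. Going from 11 heavy atoms to 6 at this position therefore produces no large shift, although the result depends on which group is taken as the reference, and no measurement on these compounds offers an explanation for either step.

Compound 2, at 3800 nM, keeps the lowest number shown, and these compounds cannot tell which part of its group on this nitrogen goes with that number. As far as these compounds go, it also remains open how the number would respond to an amine or a carboxylic acid on the pyridin-3-yl ring, or to a methylene link placing that ring one atom further from the aromatic nitrogen.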